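Trimming the Nitrogen Chain in a Lipophilicity Series

The compounds below may be only part of what the source reports. "The series", "measured", "known", "first", "only" and "open" are said of these compounds alone.

Three compounds have been measured in a physicochemical assay for lipophilicity, read by LC-MS, in phosphate buffer, measured as octanol-water partition, at pH 7.4; a lower number here means a more polar compound, a higher number a more lipophilic compound:
compound 1, `COc1cc(N(CC(C)C)c2ccc(F)c3ccccc23)cnc1C(=O)[C@H]1C[C@@H]1C(=O)O`, gives 2.2;
compound 2, `CCCN(c1cnc(C(=O)[C@H]2C[C@@H]2C(=O)O)c(OC)c1)c1ccc(F)c2ccccc12`, gives 1.8;
compound 3, `CCCN(c1cccc(C(F)(F)F)c1)c1cnc(C(=O)[C@H]2C[C@@H]2C(=O)O)c(OC)c1`, gives 1.2.

Compound 2 differs from compound 1 by hydrogen in place of methyl on a saturated chain carbon bound to two saturated chain carbons, and this change produced a number 0.40 log units lower from compound 1 to compound 2 (beyond the scatter). Compound 3 carries a different aromatic group on the nitrogen; the difference between its core and the core of compound 1 is not broken down here. Compound 3 stands lowest of the three, with compound 2 nearest and compound 1 furthest above it.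

Compound 4, `CCN(c1cccc(C(F)(F)F)c1)c1cnc(C(=O)[C@H]2C[C@@H]2C(=O)O)c(OC)c1`, has not yet been measured in this assay. It differs from compound 3 by hydrogen in place of methyl on a saturated chain carbon, two bonds along the chain from a nitrogen on an aromatic ring. Going by the values given here, this is the same kind of change as the one from compound 1 to compound 2, with a methyl leaving and a hydrogen entering on a saturated chain carbon, but the surroundings differ: in compound 1 that carbon is bound to two saturated chain carbons, whereas in compound 3 it sits two bonds along the chain from a nitrogen on an aromatic ring. Because the earlier pair showed a number 0.40 log units lower from compound 1 to compound 2 (beyond the scatter), a step of about the same size, a number 0.40 log units lower from compound 3 to compound 4 (beyond the scatter), is expected here. Compound 4 is therefore expected to give 0.8 in this assay. For compound 4 the likely range runs from 0.4 to 1.2.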

Compound 4, distribution coefficient: 0.7
For compound 4 the middle estimate is 0.10 log units above the measured one; measured number inside the range.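

In this assay, hydrogen in place of methyl gave a number 0.50 log units lower from compound 3 to compound 4 (beyond the scatter) on the core of compound 3, and the earlier change gave a number 0.40 log units lower from compound 1 to compound 2 (beyond the scatter) on the core of compound 1. Both steps are modest and beyond the scatter, and they run the same way, so within these two pairs the change carried from one core to the other, even though the surroundings of the carbon that loses the methyl differ between them. Two pairs do not make a rule for other cores or other chains, the two steps come from different starting chains on different aromatic groups, and nothing available here speaks to why the number falls in either pair.

The compounds shown leave open whether the same change, read as propyl to ethyl, would hold on the core of compound 2, where it would test the aromatic group alone with the chain held fixed, and whether a further trim from ethyl to methyl on the core of compound 4 would continue in the same direction. They also leave open how a longer chain, or a chain ending in an amine or a hydroxyl group, would read in this assay on either core.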